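The source may hold more compounds than are shown below. What is called first, only, known or untested is meant among the compounds shown, and "the series" means these compounds.

In a functional assay on MCF-10A cells (Homo sapiens) for antiproliferative activity, with a stated time of 48 h (a lower number here means that less compound is needed, a higher number that more compound is needed for the effect), compound 1 (`COc1ccc2nc(C)cc(NCc3cccc(F)c3)c2c1`) gives 11300 nM, compound 2 (`COc1ccc2nc(C)cc(NCc3ccc(F)c(F)c3)c2c1`) gives 9100 nM, and compound 3 (`COc1ccc(CNc2cc(C)nc3ccc(OC)cc23)cc1`) gives 7000 nM. The value of compound 3 is the lowest number of the three, yet it lies within the scatter of both others. Compound 4 (`COc1ccc2nc(C)cc(NCc3ccc(OC)c(F)c3)c2c1`) differs from compound 3 by fluoro in place of hydrogen on an aromatic carbon, ortho to a methoxy group and meta to a large group: fluoro in place of hydrogen on an aromatic carbon. Within the data shown here, the only measured step of this kind is a 1.2-fold lower number from compound 1 to compound 2 (0.09 log units; within the scatter), so no step beyond the scatter is expected in this assay. The expected step is a 1.1-fold lower number from compound 3 to compound 4 (0.03 log units; within the scatter). Compound 4 is estimated at 6500 nM, with an expected range from 3500 nM to 12000 nM.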

Compound 4, half-maximal effective concentration: 9000 nM
Estimate against measurement, compound 4: 1.4-fold (0.14 log units) below; the measured number falls inside the stated range.
By their numbers in this assay, from the lowest: compounds 3, 4, 2 and 1 (each within the scatter of the next).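

With a methoxy group ortho to the new atom, fluoro in place of hydrogen gives a 1.3-fold higher number from compound 3 to compound 4 (0.11 log units; within the scatter), methoxy in place of fluoro gives a 1.0-fold lower number from compound 2 to compound 4 (0.00 log units; within the scatter), and methoxy in place of hydrogen gives a 1.3-fold lower number from compound 1 to compound 4 (0.10 log units; within the scatter), so none of these changes separates the compounds. The fluoro change has now been read on two cores, and the two readings do not part beyond the scatter: the same change on two cores in this assay, a 1.2-fold lower number (0.09 log units; within the scatter) from compound 1 to compound 2 and a 1.3-fold higher number (0.11 log units; within the scatter) from compound 3 to compound 4, 1.6-fold (0.20 log units) apart, within the scatter of two such steps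

As far as these compounds go, whether an amine or a carboxylic acid on this aromatic ring would give a step beyond the scatter stays open. So does the effect of replacing the methyl group on the shared core.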